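The compounds below may be only part of what the source reports. "The series", "measured", "known", "first", "only" and "open" are said of these compounds alone.

Compound 2 `COC1=C(OC)[C@H](O)[C@H](C/C=C(\C)CC/C=C(\C)CCC=C(C)C)[C@@H](C)C1=O` stands lowest of the two numbers in a functional assay on A549 cells (Homo sapiens) for inhibition, read by sulforhodamine B assay, with a stated time of 48 h (on this read-out higher numbers stand for weaker inhibition of growth and lower numbers for stronger inhibition of growth), at 5700 nM; compound 1 `COC1=C[C@H](O)[C@H](C/C=C(\C)CC/C=C(\C)CCC=C(C)C)[C@@H](C)C1=O` gives 16400 nM, and the step of a 2.9-fold lower number from compound 1 to compound 2 (0.46 log units; beyond the scatter) is the only one measured so far. Compound 3 `COC1=C(OC)[C@H](O)[C@H](C/C=C(\C)CC/C=C(\C)C[C@H](O)C=C(C)C)[C@@H](C)C1=O` differs from compound 2 by hydroxy in place of hydrogen on a saturated chain carbon bound to a double-bonded chain carbon and a saturated chain carbon. For the measured compounds named here, no measured step touches this place on the chain; the one step known, a 2.9-fold lower number from compound 1 to compound 2 (0.46 log units; beyond the scatter), concerns the ring and does not bear on it. With nothing to fix the direction, a step of at most modest size is expected, a 1.1-fold lower number from compound 2 to compound 3 (0.06 log units; within the scatter). Compound 3 is estimated at 5000 nM, with a range from 1800 nM to 14000 nM.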

Compound 3, concentration for 50% growth inhibition: 9600 nM
For compound 3 the middle estimate is 1.9-fold (0.28 log units) below the measured one, within the range that was stated.
By their numbers in this assay, from the lowest: compounds 2, 3 and 1 (each within the scatter of the next, the first and the last beyond it).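

In this assay the chain gets its first reading: hydroxy in place of hydrogen on a saturated chain carbon bound to a double-bonded chain carbon and a saturated chain carbon gives a 1.7-fold higher number from compound 2 to compound 3 (0.23 log units; within the scatter) and so stays within the scatter. This position therefore accepts a hydroxy without a measurable change in this read-out, and compound 3 keeps the level of compound 2. Nothing available explains this result.

On these data alone, whether an amine, a methoxy or a carbonyl at this carbon would behave alike stays open. So does the effect of the same hydroxy on the core of compound 1, which lacks the ring methoxy.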